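The compounds below may be only part of what the source reports. "The series", "measured", "known", "first", "only" and "open" are said of these compounds alone.

Compound 3 `N=C(S)CCn1nc(-c2ccccc2)ccc1=O` has the highest number of the two compounds that gave a number in a functional assay on the whole organism (stomach) with Rattus norvegicus as the target; a higher number here means that more compound is needed for the effect, a lower number that less compound is needed; compound 3 gives 87.3 mg/kg. Among the measured compounds shown here, its nearest neighbour is compound 2 `N=C(S)CCCCCn1nc(-c2ccccc2)ccc1=O`, which in this assay gives 23.3 mg/kg; the one measured step, a 3.7-fold higher number from compound 2 to compound 3 (0.57 log units; beyond the scatter), concerns the length of the chain between the aromatic nitrogen and the thioamide group. Compound 1 `O=c1cccnn1CCC(=S)N1CCCC1` reaches only a limit in this assay, > 100 mg/kg, and a limit is not a number. The change to compound 4 `O=c1ccc(-c2ccccc2)nn1CCC(=S)N1CCCC1` is a group of 7 heavy atoms (5 carbon, 1 nitrogen, 1 sulfur; one five-membered non-aromatic ring with 1 hetero atom) in place of a group of 3 heavy atoms (1 carbon, 1 nitrogen, 1 sulfur; no ring), on a saturated chain carbon, two bonds along the chain from an aromatic nitrogen. For the measured compounds named here, no measured step covers this exchange; the chain-length step from compound 2 to compound 3 is of a different kind. Compound 1 carries the same group that enters and sits at the limit (the limit of > 100 mg/kg in this assay, at which 1 of the 3 values shown sits), but it lacks the phenyl ring present in compound 3 and compound 4, and that hint is a weak one. The expected step is a 1.1-fold higher number from compound 3 to compound 4 (0.06 log units; within the scatter), with a fair chance that compound 4 ends at the limit. Compound 4 is estimated at 100 mg/kg, within 35 mg/kg to 300 mg/kg.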

Compound 4, dose for half-maximal effect: > 100 mg/kg
Compound 4: a limit, no number; the forecaster's own chance of this, stated with the estimate: 45%; the middle value lies on the limit itself.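

In this assay compound 4 reaches only a limit, > 100 mg/kg, and a limit is not a number. Read as floors, an at least 1.1-fold higher number from compound 3 to compound 4 (0.05 log units; that floor lies within the scatter), so no change from the shorter unsubstituted thioamide is proven, while an at least 4.2-fold higher number from compound 2 to compound 4 (0.63 log units; beyond the scatter). The phenyl ring does not lift the group with the five-membered non-aromatic ring off the limit, so among these four compounds, the two carrying that group, compound 1 and compound 4, give no number and the two without it, compound 2 and compound 3, do: the limit of > 100 mg/kg in this assay, at which 2 of the 4 values shown sit.

The phenyl step from compound 1 to compound 4 cannot be read, since both ends are limits. As far as these compounds go, whether the five-membered ring group would give a number on a longer chain, like that of compound 2, remains open, as does the effect of a six-membered piperidine ring in its place.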